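Chain length and aryl substitution on the shared amide core

The source may report more compounds than this note shows. Statements on the series, on what has been measured and on what is new or still open speak of the compounds shown alone.

Measured so far in an assay on CHO cells for displacement of a labelled ligand from adenosine receptor A2b (Homo sapiens), read by scintillation counting, with a stated time of 75 min; a higher number here means a weaker inhibitor, a lower number a stronger inhibitor:
- compound 1 `O=C(CCc1ccccc1)Nc1nc2ccccc2c(=O)s1` gives 365 nM
- compound 2 `O=C(CCCc1ccccc1)Nc1nc2ccccc2c(=O)s1` gives > 1000 nM, a limit of the assay
- compound 3 `O=C(CCCc1ccc(Cl)c(Cl)c1)Nc1nc2ccccc2c(=O)s1` gives > 1000 nM, also a limit of the assay

Compound 3 therefore has no number, only a limit, and it shares that limit with one other compound (the limit of > 1000 nM in this assay, at which 2 of the 3 values shown sit). Compound 4 `COc1cccc(CCCC(=O)Nc2nc3ccccc3c(=O)s2)c1` differs from compound 3 in one place: 3-methoxyphenyl in place of 3,4-dichlorophenyl on a saturated chain carbon, three bonds along the chain from a carbonyl carbon.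

Among the measured compounds shown here, of the measured steps, only one touches the aryl group at that place, a step that the two limits leave unreadable from compound 2 to compound 3, and its two limits make its size unreadable. The other step, an at least 2.7-fold higher number from compound 1 to compound 2 (0.43 log units; beyond the scatter), concerns the chain and not the aryl group, so it does not bear directly on the change to compound 4. The chain of compound 4 is that of compound 2 and compound 3, both of which sit at the limit.

With no readable step for an aryl exchange at this place, compound 4 is expected to stay near the limit, a step that the limit leaves unreadable from compound 3 to compound 4; the estimate for compound 4 in this assay is 1500 nM, with a range of 500 nM to 5000 nM.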

Compound 4, inhibition constant: 302 nM
Estimate against measurement, compound 4: 5.0-fold (0.70 log units) above, outside the stated range (below it).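

In this assay, the aryl group on a saturated chain carbon, three bonds along the chain from a carbonyl carbon, proves able to shift the read-out: 3-methoxyphenyl in place of 3,4-dichlorophenyl gives an at least 3.3-fold lower number from compound 3 to compound 4 (0.51 log units; beyond the scatter). Methoxy in place of hydrogen on an aromatic carbon gives an at least 3.3-fold lower number from compound 2 to compound 4 (0.51 log units; beyond the scatter), so the chain shared by compound 2, compound 3 and compound 4 does not by itself hold a compound at the limit. Compound 2 and compound 3 each carry a limit and not a number, so both steps give only a minimum size: the limit of > 1000 nM in this assay, at which 2 of the 4 values shown sit.

Going by these compounds, the true size of each step stays open, and the step between the two limits cannot be read. Also open, on these data alone, is whether an ethoxy group, a hydroxyl group or an amine in place of methoxy would give a similar result, and how a longer chain would behave with 3-methoxyphenyl.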